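The compounds below may be only part of what the source reports. "The series", "measured", "known", "first", "only" and "open" are said of these compounds alone.

Measured compounds:
Compound 1 `O=C1[C@@H](NS(=O)(=O)c2ccc(-c3ccon3)s2)CCN1Cc1cc2c[nH]ccc-2n1`; in an assay on isolated protein for inhibition of coagulation factor X (Oryctolagus cuniculus), tested at 1 uM (a lower number here means less inhibition, a higher number more inhibition at the concentration tested (going by the name of the read-out)), compound 1 gives 17%.
Compound 2 `O=C1[C@@H](NS(=O)(=O)c2ccc(-c3ccncc3)s2)CCN1Cc1cc2[nH]cccc-2n1`; compound 2 gives 35%.
Compound 3 `O=C1[C@@H](NS(=O)(=O)c2ccc(-c3ccon3)s2)CCN1CCNc1ccncc1`; compound 3 gives 22%.

Compound 3 stands second highest of the three numbers. Its nearest neighbour is compound 1, and the step of a number 5 percentage points higher from compound 1 to compound 3 (within the scatter) lies within the scatter. Its furthest neighbour is compound 2, whose number is higher by a margin beyond the scatter.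

Compound 4 `O=C1[C@@H](NS(=O)(=O)c2ccc(-c3ccon3)s2)CCN1Cc1cc2[nH]cccc-2n1` differs from compound 3 in one place: a group of 9 heavy atoms (7 carbon, 2 nitrogen; one five-membered aromatic ring with 1 hetero atom, one six-membered aromatic ring with 1 hetero atom) in place of a group of 8 heavy atoms (6 carbon, 2 nitrogen; one six-membered aromatic ring with 1 hetero atom), on a saturated chain carbon bound to an amide-type nitrogen in a ring. For the measured compounds named here, the only measured step that bears on this change is the one from compound 1 to compound 3, which runs in the opposite direction and stayed within the scatter. Going by the values given here, compound 2 carries the same entering group as compound 4 but differs from compound 4 elsewhere, so its value shows only that this group appears in the highest of the three numbers.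

Because the step of a number 5 percentage points higher from compound 1 to compound 3 (within the scatter) was within the scatter, the reverse change is expected to move the number little. The step of a number 2 percentage points higher from compound 3 to compound 4 (within the scatter) is therefore estimated to stay within the scatter. Compound 4 is expected to give 24%, in a range from 10% to 40%.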

Compound 4, a percentage reported as inhibition, at one concentration (the size of the read-out at that concentration, not a potency): 31%
For compound 4 the middle estimate is 7 percentage points below the measured one; measured number inside the range.
By their numbers in this assay, from the lowest: compounds 1, 3, 4 and 2 (each within the scatter of the next, the first and the last beyond it).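

In this assay, for the compounds shown here, the pair of compounds carrying the two groups of equal heavy-atom count and the same ring types gives the first step at this position beyond the scatter, a number 14 percentage points higher from compound 1 to compound 4 (beyond the scatter) and so the arrangement of atoms within the group can register here even where the counts do not change. The exchange for ((pyridin-4-yl)amino)methyl gives only a number 9 percentage points higher from compound 3 to compound 4 (within the scatter) and, with compound 3 also within the scatter of compound 1, that chain-linked group cannot be separated from either of the other two groups. Going by these compounds alone, the first reading of the other position, on an aromatic carbon, is a number 4 percentage points lower from compound 2 to compound 4 (within the scatter) and shows that 1,2-oxazol-3-yl and pyridin-4-yl cannot be told apart in this assay when the group on the saturated chain carbon is held constant.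

Still open, on these data alone, is whether the step between the two isomeric groups persists with pyridin-4-yl on the aromatic carbon, and whether a primary amine on the saturated chain carbon or a carboxylic acid on the aromatic carbon would move the number beyond the scatter. No measurement at hand offers an explanation for any of these steps.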